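The source may report more compounds than this note shows. Statements on the series, on what has been measured and on what is new or still open speak of the compounds shown alone.

In a functional assay on HT-29 cells (Homo sapiens) for antiproliferative activity, read by sulforhodamine B assay, with a stated time of 72 h (on this read-out lower numbers stand for stronger inhibition and higher numbers for weaker inhibition), compound 1 `N#Cc1ccc(NC(=S)N/N=C/c2ccc3ccccc3n2)cc1` gives 15600 nM, the lowest of the numbers measured. Compound 2 `NC(=S)N/N=C/c1ccc2ccccc2n1`, with hydrogen in place of 4-cyanophenyl, gives 100000 nM. Compound 3 `S=C(N/N=C/c1ccc2ccccc2n1)Nc1ccccc1Br`, with 2-bromophenyl there, gives > 100000 nM, which is a limit of the assay. Compound 4 `FC(F)(F)c1ccc(NC(=S)N/N=C/c2ccc3ccccc3n2)cc1` differs from compound 1 by trifluoromethyl in place of cyano on an aromatic carbon, with trifluoromethyl in place of cyano on an aromatic carbon. For the measured compounds named here, two measured steps bear on this: a 6.4-fold higher number from compound 1 to compound 2 (0.81 log units; beyond the scatter) and an at least 6.4-fold higher number from compound 1 to compound 3 (0.80 log units; beyond the scatter). Both replace the whole 4-cyanophenyl, and neither changes the cyano alone, so they are only a loose guide. Starting from compound 1 at 15600 nM, no step beyond the scatter is expected in this assay. The estimated step is a 1.3-fold higher number from compound 1 to compound 4 (0.11 log units; within the scatter). Compound 4 is expected at 20000 nM, within an estimated range of 6000 nM to 70000 nM.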

Compound 4, half-maximal inhibitory concentration: 63900 nM
For compound 4 the middle estimate is 3.2-fold (0.50 log units) below the measured one; the range from low to high includes it.
By their numbers in this assay, from the lowest: compound 1; then compounds 4 and 2 (each within the scatter of the next).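

Earlier steps replaced the whole 4-cyanophenyl, whereas here only the group on the aromatic carbon para to a large group changes. In this assay, trifluoromethyl in place of cyano gives a 4.1-fold higher number from compound 1 to compound 4 (0.61 log units; beyond the scatter), so a change at this one position is enough to move the number beyond the scatter. Compound 4 still gives a number rather than a limit: the limit of > 100000 nM in this assay, at which 1 of the 4 values shown sits.

Going by these compounds, how an amine, a carboxylic acid or a methyl at this position would read stays open. With only cyano and trifluoromethyl there, no trend across groups can be drawn.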